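The compounds below may be only part of what the source reports. "The series", "measured", "known", "first", "only" and "open" are said of these compounds alone.

Compound 1 `CO[C@@]12CCN(C)C[C@H]1[C@H](c1ccc(Cl)cc1Cl)C(C#N)=C(N)O2`: 14900 nM
Compound 2 `CO[C@@]12CCN(C)C[C@H]1[C@H](c1ccc(F)cc1)C(C#N)=C(N)O2`: 19400 nM

Going by the values given here, in a functional assay on trachea (Cavia porcellus) (a higher number here means a weaker inhibitor, a lower number a stronger inhibitor), compound 2 gives 19400 nM and stands alongside compound 1, which gives 14900 nM; the only step between them, a 1.3-fold higher number from compound 1 to compound 2 (0.11 log units; within the scatter), lies within the scatter. Compound 3 `COc1ccc([C@@H]2C(C#N)=C(N)O[C@]3(OC)CCN(C)C[C@@H]23)cc1` differs from compound 2 by methoxy in place of fluoro on an aromatic carbon. Among the compounds with values here, no measured step shows methoxy entering for fluoro; the single step on the same aromatic ring was within the scatter. The step of a 1.0-fold lower number from compound 2 to compound 3 (0.01 log units; within the scatter) is therefore expected to stay within the scatter. Compound 3 is estimated at 19000 nM, in the range 7000 nM to 50000 nM.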

Compound 3, half-maximal inhibitory concentration: 23100 nM
Estimate against measurement, compound 3: 1.2-fold (0.08 log units) below; low and high end bracket the measured number.
By their numbers in this assay, from the lowest: compounds 1, 2 and 3 (each within the scatter of the next).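

In this assay, methoxy in place of fluoro on an aromatic carbon, para to a large group, gives a 1.2-fold higher number from compound 2 to compound 3 (0.08 log units; within the scatter) and so adds a hydrogen-bond acceptor at this position without a step beyond the scatter. Set against the 2,4-dichlorophenyl group, the 4-methoxyphenyl group gives a 1.6-fold higher number from compound 1 to compound 3 (0.19 log units; within the scatter) and also stays within the scatter. Nothing available explains why these numbers lie so close.

All three compounds carry a substituted phenyl on the shared core. On these data alone, whether an amine or a carboxylic acid on that ring would give a step beyond the scatter remains open.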